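Swapping an Ether for a Cyclobutyl Amide on the Side Chain

The source may report more compounds than this note shows. Statements on the series, on what has been measured and on what is new or still open speak of the compounds shown alone.

Measured compounds:
compound 1, `CNC(=O)C[C@@H]1C[C@@H](c2ccc(Cl)c(Cl)c2)[C@H](NC(=O)c2cc(-c3c(Cl)cnn3C)c(Cl)o2)CN1`: 2.64 nM
compound 2, `Cn1ncc(Cl)c1-c1cc(C(=O)N[C@@H]2CN[C@H](CCn3cncn3)C[C@H]2c2ccc(Cl)c(Cl)c2)oc1Cl`: 4.47 nM
compound 3, `COCC[C@@H]1C[C@@H](c2ccc(Cl)c(Cl)c2)[C@H](NC(=O)c2cc(-c3c(Cl)cnn3C)c(Cl)o2)CN1`: 7.01 nM

All three share one core and differ only in the group on a saturated chain carbon bound to a saturated ring carbon. In an assay for inhibition of RAC-alpha serine/threonine-protein kinase (Homo sapiens), read by HTRF, with a stated time of 1 h (on this read-out higher numbers stand for weaker inhibition and lower numbers for stronger inhibition), compound 3 gives the highest of the three numbers. Its distance to compound 2 stays within the scatter, so no order between those two can be claimed, whereas the step of a 2.7-fold higher number from compound 1 to compound 3 (0.42 log units; beyond the scatter) lies beyond it and is the one clear difference among the measured compounds.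

Compound 4, `Cn1ncc(Cl)c1-c1cc(C(=O)N[C@@H]2CN[C@H](CC(=O)NC3CCC3)C[C@H]2c2ccc(Cl)c(Cl)c2)oc1Cl`, differs from compound 3 by cyclobutylcarbamoyl in place of methoxymethyl on a saturated chain carbon bound to a saturated ring carbon. The measured step that bears on this is a 2.7-fold higher number from compound 1 to compound 3 (0.42 log units; beyond the scatter), which went the other way: an amide replaced by the ether. Among the compounds with values here, compound 4 brings an amide back, now with a cyclobutyl on its nitrogen instead of the methyl of compound 1; no measured pair tests that ring, which leaves the size of its effect uncertain. A modest move toward lower numbers in this assay is therefore expected, roughly reversing the earlier loss, as a 2.0-fold lower number from compound 3 to compound 4 (0.30 log units; within the scatter). Compound 4 is estimated at 3.5 nM, with a range from 1.5 nM to 9 nM.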

Compound 4, half-maximal inhibitory concentration: 7.98 nM
For compound 4 the middle estimate is 2.3-fold (0.36 log units) below the measured one; low and high end bracket the measured number.
By their numbers in this assay, from the lowest: compounds 1, 2, 3 and 4 (each within the scatter of the next, the first and the last beyond it).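

Replacing methyl with cyclobutyl on an amide-type nitrogen, in this assay, gives a 3.0-fold higher number from compound 1 to compound 4 (0.48 log units; beyond the scatter) and shows that the amide alone does not secure the low number of compound 1: at this position, the group carried on the amide nitrogen also counts. The cyclobutyl amide cannot be told apart from the methoxymethyl or (1H-1,2,4-triazol-1-yl)methyl side chains: the readings of a 1.1-fold higher number from compound 3 to compound 4 (0.06 log units; within the scatter) and a 1.8-fold higher number from compound 2 to compound 4 (0.25 log units; within the scatter) allow no order among these three compounds. Nothing measured here offers an explanation for the effect of the cyclobutyl group.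

On these data alone, whether the number climbs gradually with the size of the group on the amide nitrogen remains open, and an ethyl or isopropyl group there, or a primary amide with only hydrogens on that nitrogen, would help to settle this. As far as these compounds go, it also remains open how a side chain of a different kind, such as an amine or a carboxylic acid on the same saturated chain carbon, would read against the methyl amide of compound 1.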